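Replacing the ring substituent on the shared core by methylcarbamoyl

The source may hold more compounds than are shown below. What is called first, only, known or untested is meant among the compounds shown, and "the series" means these compounds.

Compound 1 `c1cc(-c2cn[nH]c2)c2c(c1)C(c1ncc[nH]1)CC2` gives 319 nM in a functional assay on CHO cells for agonist activity at Alpha-1D adrenergic receptor (Homo sapiens), read by FLIPR and calcium flux; on this read-out lower numbers stand for an effect already at smaller amounts and higher numbers for an effect only at larger amounts of compound. Compound 2 `Cn1cc(-c2cccc3c2CCC3c2ncc[nH]2)cn1` sits at the limit of > 10000 nM in this assay, at which 1 of the 2 values shown sits; its reading in this assay, > 10000 nM, is a limit and not a number. For the measured compounds named here, the only measured step, an at least 31-fold higher number from compound 1 to compound 2 (1.49 log units; beyond the scatter), is a different kind of change and bears on the present one only in that compound 1 is the sole compound with a number. Compound 3 `CNC(=O)c1cccc2c1CCC2c1ncc[nH]1` carries methylcarbamoyl in place of 1-methyl-1H-pyrazol-4-yl on an aromatic carbon. Starting from a limit, the step of an at least 3.3-fold lower number from compound 2 to compound 3 (0.52 log units; beyond the scatter) is expected to be a partial return toward a number, with wide uncertainty. Compound 3 is estimated at 3000 nM, between 500 nM and 20000 nM.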

Compound 3, half-maximal effective concentration: > 10000 nM
Compound 3: a limit, no number; the forecaster's own chance of this, stated with the estimate: 35%; middle value at least 3.3-fold (0.52 log units) from the limit.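

Compound 3 in this assay gives > 10000 nM, which is a limit and not a number. Methylcarbamoyl in place of 1H-pyrazol-4-yl on this aromatic carbon gives an at least 31-fold higher number from compound 1 to compound 3 (1.49 log units; beyond the scatter), so a group with no ring, like the 1-methyl-1H-pyrazol-4-yl of compound 2, leaves no number here. The step between compound 2 and compound 3 cannot be read, and compound 1 remains the only compound with a number: the limit of > 10000 nM in this assay, at which 2 of the 3 values shown sit.

On these data alone, how far compound 2 and compound 3 lie from the limit stays open. Also open, as far as these compounds go, is whether a primary carboxamide or a carboxylic acid at this place would give a number.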